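The source may hold more compounds than are shown below. What is called first, only, known or untested is meant among the compounds shown, and "the series" means these compounds.

Three measured members of this series share a core and differ in the substitution of the benzyl arm and of the core itself. Compound 3 `ClCc1ccc(Cn2cnc3c(Cl)nc(Cl)nc32)cc1` and compound 2 `ClCc1cccc(Cn2cnc3c(Cl)nc(Cl)nc32)c1` have the same atoms joined differently, and the difference between the two cores is not broken down here. In a functional assay on HT-29 cells (Homo sapiens) for cytotoxicity, read by sulforhodamine B assay, with a stated time of 48 h (on this read-out lower numbers stand for stronger inhibition of growth and higher numbers for weaker inhibition of growth), compound 2 gives 2390 nM, and compound 3 gives 2880 nM; the two values lie within the scatter of one another, so no order between them is claimed. Going by the values given here, compound 1 `Nc1nc(Cl)c2ncn(Cc3ccc(CCl)cc3)c2n1` carries the change (amino in place of chloro on an aromatic carbon), and in this assay compound 1 gives 9770 nM; the step of a 3.4-fold higher number from compound 3 to compound 1 (0.53 log units; beyond the scatter) is the only measured instance of this change.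

Compound 4 `Nc1nc(Cl)c2ncn(Cc3cccc(CCl)c3)c2n1` has not yet been measured. It arises from compound 2 by amino in place of chloro on an aromatic carbon, the same kind of change as that from compound 3 to compound 1, and the place lines of the two changes agree word for word. Among the compounds with values here, the expectation for compound 4 in this assay is therefore a step of about a 3.3-fold higher number from compound 2 to compound 4 (0.52 log units; beyond the scatter), resting on the single measured step of a 3.4-fold higher number from compound 3 to compound 1 (0.53 log units; beyond the scatter). On that basis compound 4 is estimated at 8000 nM, with a range from 3500 nM to 18000 nM.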

Compound 4, concentration for 50% growth inhibition: 2510 nM
Compound 4: the middle estimate sits 3.2-fold (0.50 log units) above what was measured; the whole stated range lies above it.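

In this assay, amino in place of chloro on an aromatic carbon does not carry over from one core to the other as a step of one size: the same change on two cores in this assay, a 3.4-fold higher number (0.53 log units; beyond the scatter) from compound 3 to compound 1 and a 1.1-fold higher number (0.02 log units; within the scatter) from compound 2 to compound 4, 3.2-fold (0.51 log units) apart, beyond the scatter of two such steps On the core of compound 2 the change gives no readable shift, a 1.1-fold higher number from compound 2 to compound 4 (0.02 log units; within the scatter), so a step measured on one of these cores is a poor guide to the other in this series. This rests on a single step per core and shows only that the outcome of the change depends on the core; it does not show which feature of the difference between the two cores is responsible, nor how the change would behave on any further core.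

Still open, from the compounds shown here alone, is how a methylamino or methoxy group in place of the same chloro would behave on each of the two cores. Also open, going by these compounds, is whether the gap between the steps persists when the chloromethyl group gives way to a hydroxymethyl group.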